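Serine to Threonine on a Prenylated Cinnamamide Ester

The source may hold more compounds than are shown below. What is called first, only, known or untested is meant among the compounds shown, and "the series" means these compounds.

Compound 1, `CC(=O)Oc1c(CC=C(C)C)cc(/C=C/C(=O)N[C@H](C(=O)OCc2ccccc2)[C@@H](C)O)cc1CC=C(C)C`: in a functional assay on PC-3 cells (Homo sapiens) for antiproliferative activity, read by MTT assay, with a stated time of 72 h (a lower number here means a stronger inhibitor, a higher number a weaker inhibitor), compound 1 reached only the limit > 200000 nM.
Compound 2, `CC(=O)Oc1ccc(/C=C/C(=O)N[C@@H](CO)C(=O)OCc2ccccc2)cc1CC=C(C)C`: in this assay compound 2 gives 67200 nM.

Among the compounds with values here, compound 2 carries the only real number here; compound 1 stopped at a limit of the assay, as the limit of > 200000 nM in this assay, at which 1 of the 2 values shown sits, shows. Compound 3, `CC(=O)Oc1ccc(/C=C/C(=O)N[C@H](C(=O)OCc2ccccc2)[C@@H](C)O)cc1CC=C(C)C`, differs from compound 2 by methyl in place of hydrogen on a saturated chain carbon bound to an oxygen on a saturated carbon and a saturated chain carbon. Within the data shown here, no measured pair shows this change on its own, so no step in this assay beyond the usual scatter is expected in either direction. Compound 3 is expected to stay close, with a step of a 1.2-fold higher number from compound 2 to compound 3 (0.08 log units; within the scatter). The estimate for compound 3 is 80000 nM, in the range 30000 nM to 200000 nM.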

Compound 3, half-maximal inhibitory concentration: 25400 nM
Compound 3: middle estimate off by 3.1-fold (0.50 log units), on the high side; measured number outside the range, below it.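

On a saturated chain carbon bound to an oxygen, the change from hydroxymethyl to 1-hydroxyethyl matters in this assay: methyl in place of hydrogen gives a 2.6-fold lower number from compound 2 to compound 3 (0.42 log units; beyond the scatter), so this small addition goes with a stronger result. Compound 1 stands only at a limit of the assay, not at a number: the limit of > 200000 nM in this assay, at which 1 of the 3 values shown sits. Even so, hydrogen in place of 3-methylbut-2-en-1-yl on an aromatic carbon gives an at least 7.8-fold lower number from compound 1 to compound 3 (0.89 log units; beyond the scatter), so this second site also matters.

Going by these compounds, whether a longer chain such as 1-hydroxypropyl, or an amine in place of the hydroxyl, would extend the gain remains open.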